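A few compounds are considered here, and "the series" means these few. Any claim that something is new, unique, unknown or untested is made for them only; others in the source may bear on it.

In a functional assay on the whole organism for inhibition, with Rattus norvegicus as the target, read by cytopathic effect and paw edema, at a dose of 100 mg/kg by the oral route (on this read-out higher numbers stand for more inhibition at the one dose given (going by the name of the read-out) and lower numbers for less inhibition), compound 2 `O=C(Nc1ccccc1)c1c(O)c2cccnc2n(-c2ccccc2)c1=O` gives -15%, the lowest of the three numbers; compound 1 `CCOC(=O)c1c(O)c2cccnc2n(-c2ccccc2)c1=O` gives 15.5% and compound 3 `O=C(Nc1ccc(Cl)cc1)c1c(O)c2cccnc2n(-c2ccccc2)c1=O` gives 2.5%. Compound 4 `COc1ccccc1NC(=O)c1c(O)c2cccnc2n(-c2ccccc2)c1=O` is not yet measured; it differs from compound 2 by methoxy in place of hydrogen on an aromatic carbon. For the measured compounds named here, the step that bears on this is the one in which a group replaces hydrogen on the same aromatic ring: a number 17.5 percentage points higher from compound 2 to compound 3 (beyond the scatter). The step of a number 30.5 percentage points lower from compound 1 to compound 2 (beyond the scatter) concerns the carbonyl carbon and is less informative here. On that single precedent a modest rise is expected, though one step is a weak basis and the range is kept wide. For compound 4 the expected step is a number 10 percentage points higher from compound 2 to compound 4 (within the scatter). Compound 4 is therefore estimated at -5% in this assay, between -25% and 15%.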

Compound 4, a percentage reported as inhibition, in the whole organism at one dose (the size of the read-out at that dose, not a potency): -10.1%
For compound 4 the middle estimate is 5.1 percentage points above the measured one; measured number inside the range.
By their numbers in this assay, from the lowest: compounds 2 and 4 (each within the scatter of the next); then compound 3; then compound 1.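

In this assay, methoxy on an aromatic carbon ortho to a large group leaves the number unchanged beyond the scatter (a number 4.9 percentage points higher from compound 2 to compound 4 (within the scatter)). The 2-methoxyphenyl amide does not reach the 4-chlorophenyl amide (a number 12.6 percentage points lower from compound 3 to compound 4 (beyond the scatter)) and also stays under the ethoxy compound (a number 25.6 percentage points lower from compound 1 to compound 4 (beyond the scatter)). Nothing measured here gives a reason for these differences.

From the compounds shown here alone, whether methoxy elsewhere on this ring would give a different number stays open. So does the effect of a hydroxyl group or an amine in this same place.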